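Amide variation on the ether-linked compound 2

This account rests on a few compounds, and the source may have more. Where it says the series, first, only, none or still open, it means among the compounds named here.

Three compounds in this group have numbers in an assay on microsomes from liver for inhibition of 3-hydroxy-3-methylglutaryl-coenzyme A reductase (Rattus norvegicus); a lower number here means a stronger inhibitor, a higher number a weaker inhibitor. Compound 1 `CC(C)c1c(C(=O)N(C)Cc2cccc(F)c2)nn(-c2ccc(F)cc2)c1CC[C@@H](O)C[C@@H](O)CC(=O)O` gives 4.1 nM, and compound 3 `CC(C)c1c(C(=O)N2CCC[C@H](N3CCC4C=CC=CC4C3)C2)nn(-c2ccc(F)cc2)c1CC[C@@H](O)C[C@@H](O)CC(=O)O` gives 10 nM. Compound 2 `Cc1ccc(CN(C)C(=O)c2nn(-c3ccc(F)cc3)c(OC[C@@H](O)C[C@@H](O)CC(=O)O)c2C(C)C)cc1` gives 37 nM, the highest of the three numbers, and its gap to each of the other two lies beyond the scatter, so compound 2 is the weakest inhibitor of the measured set.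

Compound 4 `CC(C)c1c(C(=O)NCc2ccccn2)nn(-c2ccc(F)cc2)c1OC[C@@H](O)C[C@@H](O)CC(=O)O` has not yet been measured. It differs from compound 2 in one place: ((pyridin-2-yl)methyl)amino in place of methyl(4-methylbenzyl)amino on a carbonyl carbon. The remainder of the structure, including the ether-linked side chain shared with compound 2, is unchanged. For the measured compounds named here, no measured pair shows this change on its own; compounds 1 and 3 carry other amide groups but also differ from compound 2 elsewhere, so they give no clean reading of the amide step. Without such a neighbour, the expectation for compound 4 is a number close to that of compound 2, with no step beyond the scatter in either direction. The expected step is a 1.6-fold higher number from compound 2 to compound 4 (0.21 log units; within the scatter). For compound 4 the estimated value in this assay is 60 nM, with a range from 15 nM to 250 nM.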

Compound 4, half-maximal inhibitory concentration: 25 nM
Compound 4: middle estimate off by 2.4-fold (0.38 log units), on the high side, within the range that was stated.
By their numbers in this assay, from the lowest: compound 1; then compound 3; then compounds 4 and 2 (each within the scatter of the next).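

For the compounds shown here, the first clean reading of this position in this assay is a 1.5-fold lower number from compound 2 to compound 4 (0.17 log units; within the scatter) when ((pyridin-2-yl)methyl)amino takes the place of methyl(4-methylbenzyl)amino on the carbonyl carbon. The two ether-linked compounds read as equal even though the exchange brings in a hydrogen-bond donor and a hydrogen-bond acceptor, a hetero atom in the aromatic ring and fewer heavy atoms, so for this pair the position accepts quite different amide groups without a difference that can be read. Nothing measured here bears on why the two numbers stay level.

The exchange alters the nitrogen substituent and the aromatic ring together, so compounds 2 and 4 cannot separate the two parts; a methyl((pyridin-2-yl)methyl)amino group on the same carbonyl carbon would do so. As far as these compounds go, it also remains open whether much smaller groups, such as dimethylamino or a simple primary amide, hold the same level on the ether-linked side chain, and whether this exchange reads the same on the carbon-linked side chain of compound 1.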